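The source may report more compounds than this note shows. Statements on the series, on what has been measured and on what is new or still open speak of the compounds shown alone.

Working notes on the series.

Two compounds carry the shared amide-linked core and have numbers in a functional assay on K562 cells (Homo sapiens) for inhibition, read by MTT assay and WST assay, with a stated time of 72 h, tested at 10 uM; on this read-out higher numbers stand for more inhibition of growth at the one concentration tested and lower numbers for less inhibition of growth. Compound 1 `CCN(CC)CCCOc1cc2ncnc(Nc3ccc4sc(C(=O)Nc5c(C)cccc5Cl)cc4c3)c2cc1OC` gives 72.5% in this assay, the higher of the two values. Compound 2 `Cc1nc(Nc2ccc3sc(C(=O)Nc4c(C)cccc4Cl)cc3c2)cc(N2CCC(C)CC2)n1` gives 20.5% in this assay, a number far lower than that of compound 1 and outside the scatter. Among the measured compounds shown here, no step between measured compounds differs in a single place, so no single change has a measured size here; compound 2 differs from compound 1 in more than one respect and shows only that its value is much lower.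

Compound 3 `COc1cc2c(Nc3ccc4sc(C(=O)Nc5c(C)cccc5Cl)cc4c3)ncnc2cc1OCCCN1CCN(C)CC1` is not yet measured. It differs from compound 1 as follows: 4-methylpiperazin-1-yl in place of diethylamino on a saturated chain carbon, three bonds along the chain from an oxygen on an aromatic ring. The amine at the end of the three-carbon chain is exchanged, the rest of compound 1 is kept. For the measured compounds named here, no measured pair speaks to this change. The expectation is that the step of a number 2.5 percentage points lower from compound 1 to compound 3 (within the scatter) stays within the usual scatter, in either direction. Compound 3 is therefore estimated at 70% in this assay, with a range from 52% to 85%.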

Compound 3, percent growth inhibition at one concentration: 51.2%
Estimate against measurement, compound 3: 18.8 percentage points above, and the stated range ends above it.
By their numbers in this assay, from the lowest: compound 2; then compound 3; then compound 1.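

Among the compounds shown here, the terminal amine of the three-carbon chain is the first place where a single change has a measured size: in this assay, 4-methylpiperazin-1-yl in place of diethylamino gives a number 21.3 percentage points lower from compound 1 to compound 3 (beyond the scatter) and the rest of compound 1 is kept. This position is therefore not indifferent to the amine it carries, even though compound 3 keeps a clear part of the growth inhibition at 51.2% in this assay. The entering group brings a six-membered non-aromatic ring with 2 hetero atoms where the leaving group has no ring, but nothing measured here gives a reason for the step.

From the compounds shown here alone, this one pair cannot separate the presence of the ring from the second ring nitrogen and its methyl group, so piperidin-1-yl, morpholin-4-yl and the unsubstituted piperazin-1-yl at the end of the same chain remain open. Also open, going by these compounds, is whether the step keeps its size on a different chain, such as 2-(diethylamino)ethyl against 2-(4-methylpiperazin-1-yl)ethyl in place of the 3-substituted propyl pair.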